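Series notes: trifluoromethyl in place of fluoro

This account rests on a few compounds, and the source may have more. Where it says the series, first, only, none or still open, it means among the compounds named here.

Measured in a functional assay on BXPC-3 cells (Homo sapiens) for inhibition, read by MTT assay; on this read-out lower numbers stand for stronger inhibition and higher numbers for weaker inhibition:
- compound 1 `COc1ccc(NC(=O)c2cc3cnc(Nc4ccc(N5CCNCC5)cn4)nc3n2C2CCCC2)cc1` gives 8970 nM
- compound 2 `COc1ccc(NC(=O)c2cc3cnc(Nc4ccc(N5CCNCC5)cn4)nc3n2C2CCCC2)c(OC)c1` gives 3650 nM
- compound 3 `O=C(Nc1ccccc1F)c1cc2cnc(Nc3ccc(N4CCNCC4)cn3)nc2n1C1CCCC1` gives 8370 nM

Compound 3 sits level with compound 1 (a 1.1-fold lower number from compound 1 to compound 3 (0.03 log units; within the scatter)) and apart from compound 2 (a 2.3-fold higher number from compound 2 to compound 3 (0.36 log units; beyond the scatter)). Compound 4 `O=C(Nc1ccccc1C(F)(F)F)c1cc2cnc(Nc3ccc(N4CCNCC4)cn3)nc2n1C1CCCC1` carries trifluoromethyl in place of fluoro on an aromatic carbon, ortho to a large group (trifluoromethyl in place of fluoro on an aromatic carbon). Among the measured compounds shown here, no measured step covers this exchange directly. For the measured compounds named here, the closest evidence is 2-fluorophenyl in place of 4-methoxyphenyl (a 1.1-fold lower number from compound 1 to compound 3 (0.03 log units; within the scatter)), and the largest step so far remains modest (a 2.5-fold lower number from compound 1 to compound 2 (0.39 log units; beyond the scatter)). A step within the scatter is therefore expected (a 1.1-fold lower number from compound 3 to compound 4 (0.05 log units; within the scatter)). For compound 4 the estimate is 7500 nM (expected range 3000 nM to 18000 nM) in this assay.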

Compound 4, half-maximal inhibitory concentration: 8040 nM
For compound 4 the middle estimate is 1.1-fold (0.03 log units) below the measured one; measured number inside the range.
By their numbers in this assay, from the lowest: compound 2; then compounds 4, 3 and 1 (each within the scatter of the next).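

In this assay, trifluoromethyl in place of fluoro on this aromatic carbon, ortho to a large group, stays within the scatter (a 1.0-fold lower number from compound 3 to compound 4 (0.02 log units; within the scatter)), so the larger group gives no readable shift here. The 2-(trifluoromethyl)phenyl amide also stays level with the 4-methoxyphenyl amide (a 1.1-fold lower number from compound 1 to compound 4 (0.05 log units; within the scatter)) and apart from the 2,4-dimethoxyphenyl amide (a 2.2-fold higher number from compound 2 to compound 4 (0.34 log units; beyond the scatter)), leaving compound 2 alone apart from the other three. No measurement at hand accounts for these results.

Going by these compounds, whether a carboxylic acid or an aminomethyl group at this position would shift the number remains open. Also open, on these data alone, is whether the lower number of compound 2 holds with other groups on the phenyl ring.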